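The source may report more compounds than this note shows. Statements on the series, on what has been measured and on what is new or still open speak of the compounds shown alone.

Compound 1 `COC(=O)Nc1c(N)nc(-c2nn(Cc3ccccc3F)c3ncccc23)nc1N`, compound 2 `CC(C)OC(=O)Nc1c(N)nc(-c2nn(Cc3ccccc3F)c3ncccc23)nc1N` and compound 3 `Nc1nc(-c2nn(Cc3ccccc3F)c3ncccc23)nc(N)c1NC(=O)OC1COC1` share one core and differ only in the group on an oxygen next to a carbonyl group. In an assay on cells for activation of Guanylate cyclase soluble subunit alpha-1 (Rattus norvegicus), read by cGMP accumulation and immunoassay, with a stated time of 10 min (a lower number here means that less compound is needed, a higher number that more compound is needed for the effect), compound 1 gives 0.3 uM, compound 2 gives 0.8 uM and compound 3 gives 2.3 uM, the highest of the three. Compound 4, `Nc1nc(-c2nn(Cc3ccccc3F)c3ncccc23)nc(N)c1NC(=O)OCC(F)(F)F`, carries the change (2,2,2-trifluoroethyl in place of oxetan-3-yl on an oxygen next to a carbonyl group). The measured steps at the oxygen next to a carbonyl group, a 2.7-fold higher number from compound 1 to compound 2 (0.43 log units; beyond the scatter), a 7.7-fold higher number from compound 1 to compound 3 (0.88 log units; beyond the scatter) and a 2.9-fold higher number from compound 2 to compound 3 (0.46 log units; beyond the scatter), show that every replacement of methyl raised the number, oxetan-3-yl most. Going by the values given here, no measured step covers 2,2,2-trifluoroethyl, so the expectation rests loosely on these. Compound 4 is expected to move back toward the lower numbers, a step of a 3.8-fold lower number from compound 3 to compound 4 (0.58 log units; beyond the scatter) in this assay. Compound 4 is estimated at 0.6 uM, with a range from 0.2 uM to 2 uM.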

Compound 4, minimum effective concentration: 0.2 uM
Compound 4: the middle estimate sits 3.0-fold (0.48 log units) above what was measured, and the stated range covers the measured number.
By their numbers in this assay, from the lowest: compounds 4 and 1 (each within the scatter of the next); then compound 2; then compound 3.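

In this assay, replacing methyl no longer has to raise the number: 2,2,2-trifluoroethyl gives a 1.5-fold lower number from compound 1 to compound 4 (0.18 log units; within the scatter), so this chain and methyl cannot be told apart here. Going by these compounds alone, the position is therefore more sensitive to which group sits on the oxygen than the earlier compounds showed, with a 12-fold lower number from compound 3 to compound 4 (1.06 log units; beyond the scatter) and a 4.0-fold lower number from compound 2 to compound 4 (0.60 log units; beyond the scatter). No measurement at hand explains these steps. Still open, going by these compounds, is how a plain ethyl group, the same chain without fluorine, or a longer chain such as 3,3,3-trifluoropropyl would read at this oxygen.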